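This account rests on a few compounds, and the source may have more. Where it says the series, first, only, none or still open, it means among the compounds named here.

In an assay on HEK293 cells for inhibition of transient receptor potential cation channel subfamily V member 1 (Homo sapiens), read by FLIPR, at pH 5.5 (a higher number here means a weaker inhibitor, a lower number a stronger inhibitor), compound 1 `Cc1ccc(N2CCN(C(=O)Nc3ccc(C(F)(F)F)cc3)CC2)nn1` gives > 10000 nM, which is a limit of the assay rather than a number. Compound 2 `O=C(Nc1ccc(C(F)(F)F)cc1)N1CCN(c2cccnn2)CC1` likewise gives > 10000 nM, again a limit. Compound 3 `O=C(Nc1nc2ccc(F)cc2s1)N1CCN(c2cccnn2)CC1` gives > 10000 nM, also a limit. Because (the limit of > 10000 nM in this assay, at which 3 of the 3 values shown sit), the change from compound 2 to compound 1, (methyl in place of hydrogen on an aromatic carbon), yields a step that the two limits leave unreadable from compound 2 to compound 1. Compound 4 `Cc1ccnnc1N1CCN(C(=O)Nc2nc3ccc(F)cc3s2)CC1` is not yet measured in this assay; it relates to compound 3 by methyl in place of hydrogen on an aromatic carbon, the same kind of change, though here the methyl sits ortho to a large group and opposite the ring nitrogen, whereas in compound 1 it sits next to the ring nitrogen and para to a large group. The difference between the cores of compound 3 and compound 2 is not broken down here. The step is expected to come out as a step that the limit leaves unreadable from compound 3 to compound 4, resting on the limit that compound 3 shows. Compound 4 is accordingly expected to give 15000 nM.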

Compound 4, half-maximal inhibitory concentration: > 25000 nM
Compound 4 ended at the assay's limit; the forecaster's own chance of this, stated with the estimate: 75%; at least 1.6-fold (0.22 log units) between middle value and limit.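

Compound 3 and compound 4 both stand at limits rather than numbers, and the step between them cannot be read. The compounds shown leave open whether a methyl in place of hydrogen changes inhibition at all.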